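Shortening a propyl chain on a quinone core

This account rests on a few compounds, and the source may have more. Where it says the series, first, only, none or still open, it means among the compounds named here.

Measured compounds:
Compound 1, `Cc1ccc(NC2=CC(=O)c3nc4n(c3C2=O)[C@H]2OC[C@@H](O)[C@H]2OC4)cc1` — 3860 nM
Compound 2, `CCCc1ccc(NC2=CC(=O)c3c(nc4n3[C@H]3OC[C@@H](O)[C@H]3OC4)C2=O)cc1` — 6030 nM
Compound 3, `CCc1ccc(NC2=CC(=O)c3nc4n(c3C2=O)[C@H]2OC[C@@H](O)[C@H]2OC4)cc1` — 3990 nM

In a functional assay on HeLa cells (Homo sapiens) for inhibition, read by sulforhodamine B assay (on this read-out higher numbers stand for weaker inhibition and lower numbers for stronger inhibition), compound 2 gives the highest of the three numbers, yet its gap to compound 3 and to compound 1 is within the usual scatter, so the three do not separate. Compound 4, `Cc1ccc(NC2=CC(=O)c3c(nc4n3[C@H]3OC[C@@H](O)[C@H]3OC4)C2=O)cc1`, shares the core of compound 2 and differs from it in one place: hydrogen in place of ethyl on a saturated chain carbon bound to an aromatic carbon. The core of compound 1 and compound 3 is not the same as that of compound 2, so their step is only a rough guide. That step, a 1.0-fold higher number from compound 1 to compound 3 (0.01 log units; within the scatter), shows that lengthening the chain on the aromatic ring by one carbon left the number where it was. Going from compound 2 to compound 4 shortens the chain by two carbons, the reverse direction of that change and somewhat larger. For the measured compounds named here, with the one comparable step flat, no move beyond the scatter is expected in this assay. The estimated step for compound 4 is a 1.3-fold lower number from compound 2 to compound 4 (0.13 log units; within the scatter), and compound 4 is expected to give about 4500 nM, within 2000 nM to 10000 nM.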

Compound 4, half-maximal inhibitory concentration: 6590 nM
The estimate for compound 4 lay 1.5-fold (0.17 log units) below the measured number; the range from low to high includes it.
By their numbers in this assay, from the lowest: compounds 1, 3, 2 and 4 (each within the scatter of the next).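

Going from 4-propylphenyl to 4-methylphenyl in this assay gives a 1.1-fold higher number from compound 2 to compound 4 (0.04 log units; within the scatter) and so stays within the scatter, even though two carbons leave the chain. Before this result, the only step at this place was a 1.0-fold higher number from compound 1 to compound 3 (0.01 log units; within the scatter), which was read on a different core and involved a smaller change, so it was only a rough guide; now the shared core of compound 2 and compound 4 also gives a flat step, and for a change of two carbons rather than one. Nothing among the available measurements explains why the number holds steady across these chains.

The chains shown are only short, plain carbon groups (methyl, ethyl and propyl), so it remains open whether a longer chain such as hexyl would move the number beyond the scatter on either core. As far as these compounds go, it also remains open whether a group of another kind on the same carbon, such as an amine or a carboxylic acid, would leave the number just as flat.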